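Trimming a methoxy from the aryl ketone side

The source may report more compounds than this note shows. Statements on the series, on what has been measured and on what is new or still open speak of the compounds shown alone.

Compound 1 `COc1cc(-c2cc(/C=C/C(=O)c3ccc(N)cc3)[nH]n2)cc(OC)c1OC`: 4020 nM
Compound 2 `COc1cc(-c2cc(/C=C/C(=O)c3ccc(Cl)c(Cl)c3)[nH]n2)cc(OC)c1OC`: 74000 nM
Compound 3 `COc1ccc(C(=O)/C=C/c2cc(-c3cc(OC)c(OC)c(OC)c3)n[nH]2)cc1OC`: 2830 nM

All three share the same core; they differ only in the aryl group attached to the carbonyl carbon. In a functional assay on UACC-257 cells (Homo sapiens) for inhibition, read by sulforhodamine B assay, with a stated time of 48 h (on this read-out lower numbers stand for stronger inhibition of growth and higher numbers for weaker inhibition of growth), compound 3 gives the lowest of the three numbers. One of the two steps that end at it, a 1.4-fold lower number from compound 1 to compound 3 (0.15 log units; within the scatter), means the two compounds in that step cannot be told apart here, whereas the other, a 26-fold lower number from compound 2 to compound 3 (1.42 log units; beyond the scatter), is far beyond the scatter. Compound 4 `COc1ccc(C(=O)/C=C/c2cc(-c3cc(OC)c(OC)c(OC)c3)n[nH]2)cc1` has not yet been measured. It differs from compound 3 by hydrogen in place of methoxy on an aromatic carbon.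

Within the data shown here, no measured step removes a single methoxy group. The steps that exist swap one whole aryl group for another, and one of them, a 1.4-fold lower number from compound 1 to compound 3 (0.15 log units; within the scatter), shows that quite different groups on this carbon can give numbers within the scatter of each other, while an 18-fold higher number from compound 1 to compound 2 (1.27 log units; beyond the scatter) shows that a change there can also be large. Keeping one methoxy in place, the expectation is a step of a 1.2-fold higher number from compound 3 to compound 4 (0.09 log units; within the scatter), not beyond the scatter. Compound 4 is therefore estimated at 3500 nM, with a range from 1200 nM to 11000 nM in this assay.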

Compound 4, concentration for total growth inhibition: 3740 nM
For compound 4 the middle estimate is 1.1-fold (0.03 log units) below the measured one; the range from low to high includes it.
By their numbers in this assay, from the lowest: compounds 3, 4 and 1 (each within the scatter of the next); then compound 2.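

In this assay, taking a single methoxy off the 3,4-dimethoxyphenyl group gives a 1.3-fold higher number from compound 3 to compound 4 (0.12 log units; within the scatter), so this one group can go without a change that the assay can detect. The 4-methoxyphenyl group also cannot be told apart from the 4-aminophenyl group, with a 1.1-fold lower number from compound 1 to compound 4 (0.03 log units; within the scatter), so methoxy and amino on that aromatic carbon read alike here. The 3,4-dichlorophenyl group alone stands apart, with a 20-fold lower number from compound 2 to compound 4 (1.30 log units; beyond the scatter), which extends to compound 4 the gap already seen for the other two aryl groups.

No measured evidence explains why these groups read as they do. As far as these compounds go, it remains open whether a plain phenyl group, with hydrogen in place of the remaining methoxy, or a hydroxyl group on that carbon would keep the number in this range.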